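Swapping acetyl for dimethylamino on a pyrazole series

The source may hold more compounds than are shown below. What is called first, only, known or untested is meant among the compounds shown, and "the series" means these compounds.

The measured compounds:
- compound 1, `COc1cc(C)cc(-c2c(-c3ccnc(-c4ccc(C(C)=O)cc4)c3)cnn2CC#N)c1`, 70%
- compound 2, `COc1cc(C)cc(-c2nn(CC#N)cc2-c2ccc(-c3cccc(C(C)=O)c3)nc2)c1`, 68%
- compound 3, `Cc1cc(O)cc(-c2nn(CC#N)cc2-c2ccnc(-c3ccc(Oc4ccccc4)cc3)c2)c1`, 72%

Three compounds were tested in a functional assay on OVCAR-5 cells (Homo sapiens) for cytotoxicity, read by sulforhodamine B assay, with a stated time of 48 h, tested at 0.01 uM; on this read-out higher numbers stand for a weaker effect at the one concentration tested and lower numbers for a stronger effect. Compound 1 gives 70%, the second highest of the three numbers. Its nearest neighbour is compound 2, and compound 3 is the furthest from it; both gaps fall within the usual scatter, so the three compounds cannot be ranked against one another on these numbers. Going by the values given here, none of the three pairs differs in a single place, so no clean step between measured compounds is available.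

Compound 4, `COc1cc(C)cc(-c2c(-c3ccnc(-c4ccc(N(C)C)cc4)c3)cnn2CC#N)c1`, is the next compound and has not yet been measured. It differs from compound 1 in one place: dimethylamino in place of acetyl on an aromatic carbon. The change is confined to a group para to a large group on a six-membered aromatic ring of carbon only.

Among the compounds with values here, with no measured step of this kind to lean on, compound 4 is expected to stay close to compound 1 in this assay, with the step of a number 2 percentage points lower from compound 1 to compound 4 (within the scatter) expected to lie within the scatter. Compound 4 is therefore estimated at 68%, with a range from 50% to 85%.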

Compound 4, a percentage reported as activity, at one concentration (the size of the read-out at that concentration, not a potency): 73%
The estimate for compound 4 lay 5 percentage points below the measured number, and the stated range covers the measured number.
By their numbers in this assay, from the lowest: compounds 2, 1, 3 and 4 (each within the scatter of the next).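

In this assay, dimethylamino in place of acetyl on an aromatic carbon, para to a large group, gives a number 3 percentage points higher from compound 1 to compound 4 (within the scatter). Going by these compounds alone, this is the first comparison here that turns on one place alone, and on this read-out the 4-acetylphenyl and 4-(dimethylamino)phenyl forms of the shared core cannot be told apart, even though the group that leaves carries a double bond outside the aromatic rings and the group that enters does not. No measurement shown here bears on why the two groups read alike.

From the compounds shown here alone, what stays open is whether any group at this place would move the read-out beyond the scatter, for instance a carboxylic acid, a primary amine or a longer alkyl chain ending in a morpholine. Going by these compounds, it is also open whether the same exchange would read alike on the core of compound 2, where the acetyl sits differently, and since only one concentration is reported, this single step says nothing about potency.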